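From a methoxyphenyl group to a single bromine

The source may hold more compounds than are shown below. What is called first, only, known or untested is meant among the compounds shown, and "the series" means these compounds.

Compound 3 `CC[C@@H](Nc1c(C#N)c(-c2ccc(-c3ccccc3OC)cc2)nc2cnccc12)C(N)=O` is measured in a physicochemical assay for lipophilicity, read by HPLC, at pH 7.5 (on this read-out lower numbers stand for lower lipophilicity and higher numbers for higher lipophilicity), at 2.7. Compound 1 `CC[C@@H](Nc1c(C#N)c(-c2ccc(-c3cccc(OC)c3)cc2)nc2cnccc12)C(N)=O` gives 2.7, and the two stand level: the step of no change at the digits printed from compound 1 to compound 3 (within the scatter) stays within the usual scatter. Compound 2 `CC[C@H](Nc1c(C#N)c(-c2ccc(Br)cc2)nc2cnccc12)C(N)=O`, which carries bromo where the other two carry a methoxyphenyl group, gives 2.3, a lower number that lies beyond the scatter from compound 3.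

Compound 4 `CC[C@@H](Nc1c(C#N)c(-c2ccc(Br)cc2)nc2cnccc12)C(N)=O` has not yet been measured. It differs from compound 3 by bromo in place of 2-methoxyphenyl on an aromatic carbon. Within the data shown here, no measured step covers exactly this exchange, so the only guide is that compound 2 also bears bromo at that place and sits at 2.3, below compound 3. Shedding the methoxyphenyl group and keeping only bromo is therefore expected to lower the reading in this assay by a step of about a number 0.40 log units lower from compound 3 to compound 4 (beyond the scatter), beyond the scatter. For compound 4 the estimate is 2.3, with a likely range from 2 to 2.6.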

Compound 4, distribution coefficient: 2.2
The estimate for compound 4 lay 0.10 log units above the measured number; the measured number falls inside the stated range.
By their numbers in this assay, from the lowest: compounds 4 and 2 (each within the scatter of the next); then compounds 1 and 3 (each within the scatter of the next).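

In this assay, putting bromo on this aromatic carbon in place of either methoxyphenyl group gives a step beyond the scatter: a number 0.50 log units lower from compound 3 to compound 4 (beyond the scatter) for the 2-methoxyphenyl group, and a number 0.50 log units lower from compound 1 to compound 4 (beyond the scatter) for the 3-methoxyphenyl group. Inverting the stereocentre at the saturated chain carbon gives a number 0.10 log units lower from compound 2 to compound 4 (within the scatter), so the two drawn configurations cannot be told apart on this read-out while bromo is in place. That comparison speaks for the stereocentre alone because nothing else changes: the fact that compounds 2 and 4 differ only in the configuration as drawn

The compounds shown leave open how this assay would read with a different group on this carbon, such as an amine or a carboxylic acid. They also leave open whether the two configurations would still stand level with a methoxyphenyl group in place of bromo.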